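The compounds below may be only part of what the source reports. "The series", "measured", "known", "first", "only" and "open" are said of these compounds alone.

Measured so far:
- compound 1, `Cn1ncc(Cl)c1-c1cc(C(=O)N[C@@H]2CN[C@H](CC(N)=O)C[C@H]2c2ccc(Cl)c(Cl)c2)oc1Cl`, an assay for inhibition of RAC-alpha serine/threonine-protein kinase (Homo sapiens), read by HTRF, with a stated time of 1 h; a lower number here means a stronger inhibitor, a higher number a weaker inhibitor: 3.24 nM
- compound 2, `Cn1ncc(Cl)c1-c1cc(C(=O)N[C@@H]2CN[C@H](CC(=O)NCCO)C[C@H]2c2ccc(Cl)c(Cl)c2)oc1Cl`, this assay: 1.41 nM

Among the measured compounds shown here, compound 2 gives the lower of the two numbers; the single step of a 2.3-fold lower number from compound 1 to compound 2 (0.36 log units; beyond the scatter) is modest but beyond the scatter.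

Compound 3, `COCC[C@@H]1C[C@@H](c2ccc(Cl)c(Cl)c2)[C@H](NC(=O)c2cc(-c3c(Cl)cnn3C)c(Cl)o2)CN1`, is not yet measured. Its change from compound 2 is methoxymethyl in place of (2-hydroxyethyl)carbamoyl on a saturated chain carbon bound to a saturated ring carbon. For the measured compounds named here, no measured step bears on it directly; the one step known concerns only the substituent on the amide nitrogen, not the amide itself. Compound 3 is therefore expected to give a number near that of compound 1 or somewhat higher, the step of a 3.2-fold higher number from compound 2 to compound 3 (0.50 log units; beyond the scatter) being the estimate. For compound 3 the expected value is 4.5 nM, range 1.5 nM to 14 nM.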

Compound 3, half-maximal inhibitory concentration: 7.01 nM
The estimate for compound 3 lay 1.6-fold (0.19 log units) below the measured number; the range from low to high includes it.
By their numbers in this assay, from the lowest: compound 2; then compound 1; then compound 3.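

In this assay the amide on this chain is not essential: methoxymethyl in place of (2-hydroxyethyl)carbamoyl gives a 5.0-fold higher number from compound 2 to compound 3 (0.70 log units; beyond the scatter) and methoxymethyl in place of carbamoyl gives a 2.2-fold higher number from compound 1 to compound 3 (0.34 log units; beyond the scatter) as the corresponding step from the simpler amide. Both steps are modest yet beyond the scatter, so across these three compounds each amide gives a lower number than the ether. Nothing measured here accounts for this difference.

Still open, on these data alone, is how a primary amine or a carboxylic acid would read on the same saturated chain carbon. Also open, as far as these compounds go, is whether a longer chain ending in hydroxyl would lower the number further.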